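Ether side chain variation on the shared core

The source may report more compounds than this note shows. Statements on the series, on what has been measured and on what is new or still open speak of the compounds shown alone.

Compound 1 `Cc1noc(C)c1COC1CC(=O)Nc2c1c(C)nn2-c1ncnc2nc[nH]c12` and compound 2 `CCC(C(=O)NC1CC(=O)Nc2c1c(C)nn2-c1ncnc2nc[nH]c12)c1ccccc1` carry the same core and differ only outside it. In a functional assay on HEK293 cells for agonist activity at G-protein coupled receptor 39 (Homo sapiens), read by scintillation proximity assay and inositol phosphate accumulation, with a stated time of 75 min, in the presence of a further agent that is not named here (on this read-out higher numbers stand for an effect only at larger amounts of compound and lower numbers for an effect already at smaller amounts), compound 1 gives 5 nM. Compound 2 gives 5 nM in this assay. Compound 1 thus stands level with compound 2 at the digits shown; the two values lie within the scatter of each other, and no order between them is claimed.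

Compound 3 `Cc1cc(C)n(CCOC2CC(=O)Nc3c2c(C)nn3-c2ncnc3nc[nH]c23)n1` has not yet been measured in this assay. It differs from compound 1 by (3,5-dimethyl-1H-pyrazol-1-yl)methyl in place of 3,5-dimethyl-1,2-oxazol-4-yl on a saturated chain carbon bound to an oxygen on a saturated carbon. Among the measured compounds shown here, no measured pair shows a change of this kind, so the step has no precedent among the measured compounds. Because compound 1 sits at 5 nM and compound 2 at 5 nM while differing outside the core, only a small step is expected here. The step of a 1.6-fold higher number from compound 1 to compound 3 (0.20 log units; within the scatter) is expected to lie within the scatter, or at most slightly beyond it towards larger amounts of compound. Compound 3 is estimated at 8 nM, with an expected range from 2 nM to 30 nM.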

Compound 3, half-maximal effective concentration: 16 nM
Estimate against measurement, compound 3: 2.0-fold (0.30 log units) below; low and high end bracket the measured number.
By their numbers in this assay, from the lowest: compounds 1 and 2 (each within the scatter of the next); then compound 3.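

The ether position is not indifferent to its side chain. In this assay, (3,5-dimethyl-1H-pyrazol-1-yl)methyl in place of 3,5-dimethyl-1,2-oxazol-4-yl gives a 3.2-fold higher number from compound 1 to compound 3 (0.51 log units; beyond the scatter) as a modest step, the first difference in this set that lies beyond the scatter, while compound 3 at 16 nM still acts at small amounts of compound. Read one bond further out, the change is (3,5-dimethyl-1,2-oxazol-4-yl)methyl to 2-(3,5-dimethyl-1H-pyrazol-1-yl)ethyl, so the heterocycle and the chain length change together, and nothing available explains the step.

Still open, going by these compounds, is which part of the change carries the step, a question that a 2-(3,5-dimethyl-1,2-oxazol-4-yl)ethyl side chain or a (3,5-dimethyl-1H-pyrazol-1-yl)methyl side chain on the same ether oxygen would separate. Also open is how this position responds to a chain ending in an amine or a carboxylic acid, neither of which appears among the compounds shown.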